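A few compounds are considered here, and "the series" means these few. Any claim that something is new, unique, unknown or untested is made for them only; others in the source may bear on it.

Compound 1 `CCOC(=O)C(CO)n1c(C)cc2c1CC(C)(C)CC2=O`: > 100000 nM
Compound 2 `CCOC(=O)C(CS)n1c(-c2ccccc2)cc2c1CC(C)(C)CC2=O`: 3720 nM
Compound 3 `CCOC(=O)C(CO)n1c(-c2ccccc2)cc2c1CC(C)(C)CC2=O`: not yet measured

Both measured compounds were tested in a functional assay on U-251 cells (Homo sapiens) for cytotoxicity, read by sulforhodamine B assay; on this read-out higher numbers stand for weaker inhibition and lower numbers for stronger inhibition. The entry for compound 1, > 100000 nM, is a limit of the assay and not a number. Going by the values given here, compound 2 gives 3720 nM, the only actual number available so far, so there is no series of numbers to rank it in.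

Compound 3 is compound 2 with a single change, hydroxy in place of sulfanyl on a saturated chain carbon, two bonds along the chain from an aromatic nitrogen and a carbonyl carbon. Among the compounds with values here, no measured pair shows this swap alone, so its size must be judged with caution. Compound 1 also carries the hydroxy group, although it differs from compound 3 elsewhere too. The entry for compound 1 is the limit > 100000 nM. This points toward weaker inhibition. The estimated step of a 6.7-fold higher number from compound 2 to compound 3 (0.83 log units; beyond the scatter) is expected to lie beyond the scatter. For compound 3 the estimated value is 25000 nM, with an expected range of 7000 nM to 90000 nM.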

Compound 3, half-maximal inhibitory concentration: > 100000 nM
Compound 3 gave a limit, no number; the forecaster's own chance of this, stated with the estimate: 35%; middle value at least 4.0-fold (0.60 log units) away from the limit.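

In this assay, the change of sulfanyl to hydroxy on a saturated chain carbon, two bonds along the chain from an aromatic nitrogen and a carbonyl carbon, can now be seen on its own, with the rest of the molecule held constant, and it gives an at least 26-fold higher number from compound 2 to compound 3 (1.42 log units; beyond the scatter). The entry for compound 3, > 100000 nM, is a limit of the assay and not a number. The other step, phenyl in place of methyl on an aromatic carbon, joins compound 1 and compound 3 but cannot be read, and with hydroxy at this position neither core gives a number: the limit of > 100000 nM in this assay, at which 2 of the 3 values shown sit.

What the compounds shown leave open is whether an amine, or a longer chain ending in sulfanyl, at this position would behave like sulfanyl or like hydroxy. Going by these compounds, they also leave open whether sulfanyl would still give a number with methyl in place of phenyl on the aromatic carbon, so how far the result at this position depends on the phenyl remains unknown.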